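Ring Contraction on the Thiocarbonyl Nitrogen of Compound 2

This account rests on a few compounds, and the source may have more. Where it says the series, first, only, none or still open, it means among the compounds named here.

Of the compounds shown here, three sharing one core have been tested in a functional assay on HeLa cells (Homo sapiens) for antiproliferative activity, read by MTT assay, with a stated time of 72 h; on this read-out higher numbers stand for weaker inhibition and lower numbers for stronger inhibition. Compound 1 `O=c1c(SC(=S)N2CCCCC2)coc2ccccc12` gives 9000 nM in this assay. Compound 2 `O=c1c(CSC(=S)N2CCCCC2)coc2cc(Cl)ccc12` gives 440 nM, and compound 3 `O=c1c(Cl)c(CSC(=S)N2CCCC2)oc2ccccc12` gives 700 nM. Compound 2 thus holds the lowest number of the three; the gap to compound 3 falls within the scatter of repeated measurements, while the gap to compound 1 lies well beyond it, so compound 2 and compound 3 cannot be placed in order against each other, but both stand clearly apart from compound 1.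

Compound 4 `O=c1c(CSC(=S)N2CCCC2)coc2cc(Cl)ccc12` has not yet been measured. It differs from compound 2 in one place: pyrrolidin-1-yl in place of piperidin-1-yl on a thiocarbonyl carbon. Among the measured compounds shown here, no pair among the measured compounds isolates this exact change, so the expected step rests on the closeness of compound 2 and compound 3 alone. In this assay the step from compound 2 to compound 4 is expected to be small and to stay within the scatter, with at most a slight drift toward a higher number, a 1.4-fold higher number from compound 2 to compound 4 (0.13 log units; within the scatter). Compound 4 is therefore estimated at 600 nM, with a range from 250 nM to 1500 nM.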

Compound 4, half-maximal inhibitory concentration: 1300 nM
The estimate for compound 4 lay 2.2-fold (0.34 log units) below the measured number, and the stated range covers the measured number.
By their numbers in this assay, from the lowest: compounds 2, 3 and 4 (each within the scatter of the next, the first and the last beyond it); then compound 1.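

In this assay, among the compounds shown here, pyrrolidin-1-yl in place of piperidin-1-yl on a thiocarbonyl carbon gives a 3.0-fold higher number from compound 2 to compound 4 (0.47 log units; beyond the scatter), and this pair is the first to isolate the change. For the compounds shown here, the step is modest but lies beyond the scatter, so the read-out at this position does respond to replacing the six-membered ring with the five-membered one, which the earlier compounds, none of them differing in one place, could not show. Nothing shown here gives a measured reason for this step.

With only these two rings on the thiocarbonyl carbon, two points cannot be told apart: whether the trend continues to a larger ring such as azepan-1-yl, and whether a ring oxygen, as in morpholin-4-yl, is tolerated. From the compounds shown here alone, an open-chain amine such as diethylamino also remains open at this position.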